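The compounds below may be only part of what the source reports. "The series", "measured", "known", "first", "only" and "open" are said of these compounds alone.

Of the compounds shown here, two from one series have been measured in a functional assay on MCF7 cells (Homo sapiens), tested at 5 uM; a lower number here means a stronger effect, a higher number a weaker effect of the compound at the concentration tested. Compound 1 `Cc1c(C)c2c(c(C)c1OC/C=C/c1ccccc1)CCC(C)(COc1ccc(/C=C3\SC(=O)NC3=O)cc1)O2` gives 65% in this assay. Compound 2 `CCOc1cc(/C=C2\SC(=O)NC2=O)ccc1OCC1(C)CCc2c(C)c(OCC=C(C)C)c(C)c(C)c2O1` gives 84% in this assay, the highest of the two numbers and a difference from compound 1 that lies beyond the usual scatter. Compound 3 `CC(C)=CCOc1c(C)c(C)c2c(c1C)CCC(C)(COc1ccc(/C=C3\SC(=O)NC3=O)cc1)O2` has not yet been measured. Compared with compound 2 it carries hydrogen in place of ethoxy on an aromatic carbon. Compound 1 also lacks this ethoxy, so compound 3 is expected to move toward it, with a step of a number 12 percentage points lower from compound 2 to compound 3 (beyond the scatter) expected in this assay. For compound 3 the estimated value is 72%, expected between 55% and 90%.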

Compound 3, a percentage reported as activity, at one concentration (the size of the read-out at that concentration, not a potency): 21%
Compound 3: the middle estimate sits 51 percentage points above what was measured; the whole stated range lies above it.
By their numbers in this assay, from the lowest: compound 3; then compound 1; then compound 2.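

In this assay hydrogen in place of ethoxy on this aromatic carbon gives a number 63 percentage points lower from compound 2 to compound 3 (beyond the scatter), so this one place on the ring strongly changes the effect of the compound. With no ethoxy on that ring, the other end of the molecule matters too: 2-methylprop-1-en-1-yl in place of 2-phenylethenyl gives a number 44 percentage points lower from compound 1 to compound 3 (beyond the scatter), which leaves compound 3 with the strongest effect of the three. Nothing available explains either step. As far as these compounds go, whether a methoxy group or a fluorine atom at this place behaves like hydrogen or like ethoxy stays open, as does whether ethoxy has the same effect alongside the 2-phenylethenyl chain.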